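Working notes on a four-compound series, one cytotoxicity read-out

The compounds below may be only part of what the source reports. "The series", "measured", "known", "first", "only" and "open" are said of these compounds alone.

Measured in an ADME assay on BV-2 cells (Mus musculus) for cytotoxicity, with a stated time of 24 h, tested at 50 uM; on this read-out higher numbers stand for a weaker effect at the one concentration tested and lower numbers for a stronger effect:
compound 1 `COc1ccccc1S(=O)(=O)/C=C/c1ccccn1` gives 100%
compound 2 `COc1ccccc1S(=O)(=O)/C=C/c1ncccc1Cl` gives 100%
compound 3 `COc1ccc(S(=O)(=O)/C=C/c2cccnc2)cc1` gives 85.8%

Compound 2 is compound 1 with chloro in place of hydrogen on an aromatic carbon. The step in this assay is no change at the digits printed from compound 1 to compound 2 (within the scatter). Compound 3 carries the same atoms as compound 1 joined differently; how the two cores differ is not broken down here. Compound 3 sits lowest of the three numbers, beyond the scatter from both compound 1 and compound 2.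

Compound 4 `COc1ccc(S(=O)(=O)/C=C/c2cccnc2Cl)cc1` is still to be measured in this assay. It is compound 3 with chloro in place of hydrogen on an aromatic carbon. This is the same kind of change as from compound 1 to compound 2, not the same: in compound 4 the chloro sits next to the ring nitrogen, whereas in compound 2 it sits two atoms from the ring nitrogen. For the measured compounds named here, only one earlier pair carries this change, and that step was flat within the scatter. Starting from compound 3 at 85.8%, the step for compound 4 is expected to be a number 0.2 percentage points higher from compound 3 to compound 4 (within the scatter), because the change from compound 1 to compound 2 gave no change at the digits printed from compound 1 to compound 2 (within the scatter). Compound 4 is therefore estimated at 86%, between 70% and 100%.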

Compound 4, a percentage reported as activity, at one concentration (the size of the read-out at that concentration, not a potency): 76.3%
The estimate for compound 4 lay 9.7 percentage points above the measured number; the range from low to high includes it.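

In this assay, chloro in place of hydrogen on an aromatic carbon gives a number 9.5 percentage points lower from compound 3 to compound 4 (within the scatter). Set beside the earlier pair, the two steps cannot be told apart: the same change on two cores in this assay, no change at the digits printed (within the scatter) from compound 1 to compound 2 and a number 9.5 percentage points lower (within the scatter) from compound 3 to compound 4, 9.5 percentage points apart, within the scatter of two such steps. On these two pairs the change therefore carries from one core to the other without a difference that stands clear of the scatter, but two steps at a single concentration do not show that the cores respond alike, and the place of the chloro relative to the ring nitrogen also differs between the pairs, so core and place cannot be separated.

The compounds shown leave open whether the flat reading holds for any group other than chloro on this ring, since an amine or a carboxylic acid in that place stands among none of them. Also open, on these data alone, is whether chloro at one fixed place relative to the ring nitrogen would give the same step on both cores.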